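Phenylsulfonyl in Place of Bromophenyl: an Expected Rise

The compounds below may be only part of what the source reports. "The series", "measured", "known", "first", "only" and "open" are said of these compounds alone.

Compound 3 `CCOC(=O)c1cnc(-c2cccc(Br)c2)nc1NN1C(=O)C=C(C)C1=O` gives 700 nM in a functional assay on Jurkat cells for inhibition of nuclear factor NF-kappa-B complex (Homo sapiens) (a lower number here means a stronger inhibitor, a higher number a weaker inhibitor), the second highest of three numbers: compound 2 `CCOC(=O)c1cnc(-c2ccc(Cl)cc2)nc1NN1C(=O)C=C(C)C1=O` gives 300 nM, while compound 1 `CCOC(=O)c1cnc(C)nc1NN1C(=O)C=C(C)C1=O` gives 16000 nM. The measured steps are a 23-fold lower number from compound 1 to compound 3 (1.36 log units; beyond the scatter), a 53-fold lower number from compound 1 to compound 2 (1.73 log units; beyond the scatter), and a 2.3-fold higher number from compound 2 to compound 3 (0.37 log units; beyond the scatter). Compound 4 `CCOC(=O)c1cnc(S(=O)(=O)c2ccccc2)nc1NN1C(=O)C=C(C)C1=O` differs from compound 3 by phenylsulfonyl in place of 3-bromophenyl on an aromatic carbon. Going by the values given here, no measured step exchanges an aryl group for a phenylsulfonyl group; the only guidance is that both aryl groups lowered the number far beneath methyl in this assay, so the sulfonyl variant is expected to lie somewhere in that span, closer to the aryl compounds than to methyl. Compound 4 is therefore estimated at 2500 nM, with a range of 400 nM to 16000 nM, and the expected step is a 3.6-fold higher number from compound 3 to compound 4 (0.55 log units; beyond the scatter).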

Compound 4, half-maximal inhibitory concentration: 10000 nM
Compound 4: middle estimate off by 4.0-fold (0.60 log units), on the low side; the measured number falls inside the stated range.
By their numbers in this assay, from the lowest: compound 2; then compound 3; then compounds 4 and 1 (each within the scatter of the next).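

Carrying a six-membered aromatic ring is not enough at this position: with phenylsulfonyl in place of the aryl groups, a 14-fold higher number from compound 3 to compound 4 (1.15 log units; beyond the scatter) and a 33-fold higher number from compound 2 to compound 4 (1.52 log units; beyond the scatter) in this assay. Against methyl, the change gives a 1.6-fold lower number from compound 1 to compound 4 (0.20 log units; within the scatter) and so no gain that can be told apart, which means the large improvement holds only for the 3-bromophenyl and 4-chlorophenyl compounds. Nothing available explains this loss.

Going by these compounds, whether a phenoxy, benzyl or anilino group would track the aryl compounds or compound 4 remains open. So does whether a halogen on the phenylsulfonyl ring would change compound 4.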